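The compounds below may be only part of what the source reports. "The series", "measured", "known", "first", "only" and "open" are said of these compounds alone.

Compound 1 `COc1cccc(Cn2cc(CCCCC[C@@H]3SC[C@@H]4NC(=O)N[C@@H]43)nn2)c1` is one of the two measured compounds. In an assay on isolated protein for inhibition of biotin--protein ligase (Homo sapiens), read by scintillation counting, with a stated time of 10 min (on this read-out higher numbers stand for weaker inhibition and lower numbers for stronger inhibition), compound 1 gives only a limit, > 16000 nM. Compound 2 `O=C1N[C@H]2[C@H](CS[C@H]2CCCCCc2cn(Cc3ccc(C(F)(F)F)cc3)nn2)N1` reaches only a limit in this assay as well, > 16000 nM. The step from compound 1 to compound 2 a step that the two limits leave unreadable from compound 1 to compound 2 is thus not readable, and the limit of > 16000 nM in this assay, at which 2 of the 2 values shown sit, is all that the data hold. Compound 3 `O=C1N[C@H]2[C@H](CS[C@H]2CCCCCc2cn(Cc3ccccc3Br)nn2)N1` differs from compound 2 by 2-bromophenyl in place of 4-(trifluoromethyl)phenyl on a saturated chain carbon bound to an aromatic nitrogen. Among the measured compounds shown here, no measured step in this assay can be sized because both values sit at the limit of > 16000 nM in this assay, at which 2 of the 2 values shown sit. Compound 3 is therefore expected to remain at the limit, with an estimated 20000 nM. The expected step is a step that the limit leaves unreadable from compound 2 to compound 3.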

Compound 3, inhibition constant: > 16000 nM
Compound 3 ended at the assay's limit (the forecaster's own chance of this, stated with the estimate: 80%); the middle value does not contradict the limit.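

No step can be read among compound 1, compound 2 and compound 3, and the data hold only a limit: the limit of > 16000 nM in this assay, at which 3 of the 3 values shown sit. The compounds shown leave open whether these three differ at all in inhibition of the protein.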